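The compounds below may be only part of what the source reports. "The series", "measured", "known", "first", "only" and "open" are said of these compounds alone.

Working notes on the series. In a functional assay on Bel-7402 cells (Homo sapiens) for inhibition, read by MTT assay, with a stated time of 24 h, tested at 100 ug/mL (on this read-out lower numbers stand for less inhibition of growth and higher numbers for more inhibition of growth at the one concentration tested), compound 1 (`O=C(CCCCC(S)CCS)Nc1ccccc1`) gives 7.67%, compound 2 (`O=C(CCCCC(S)CCS)Nc1ccc(F)cc1`) gives 11.7% and compound 3 (`COc1ccc(NC(=O)CCCCC(S)CCS)cc1`) gives 22.5%, so compound 3 stands highest of the three. Compound 4 (`O=C(CCCCC(S)CCS)Nc1ccc([N+](=O)[O-])cc1`) is next: nitro in place of methoxy on an aromatic carbon, with nitro in place of methoxy para to a large group. Going by the values given here, three measured steps bear on this. Fluoro in place of hydrogen gives a number 4 percentage points higher from compound 1 to compound 2 (within the scatter), methoxy in place of hydrogen gives a number 14.8 percentage points higher from compound 1 to compound 3 (beyond the scatter), and methoxy in place of fluoro gives a number 10.8 percentage points higher from compound 2 to compound 3 (beyond the scatter). Among the compounds with values here, no nitro compound has been measured, so the evidence is indirect. Removing methoxy is expected to cost a modest step, close in size to those two methoxy steps. The expected change is a number 9.5 percentage points lower from compound 3 to compound 4 (within the scatter). Compound 4 is estimated at 13%, with an expected range of 4% to 28%.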

Compound 4, percent growth inhibition at one concentration: 33.4%
Estimate against measurement, compound 4: 20.4 percentage points below, outside the stated range (above it).
By their numbers in this assay, from the lowest: compounds 1 and 2 (each within the scatter of the next); then compound 3; then compound 4.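

Nitro gives a number 10.9 percentage points higher from compound 3 to compound 4 (beyond the scatter) in this assay at this place, para to a large group, so the rise seen with methoxy does not depend on methoxy itself. Nitro also gives a number 21.7 percentage points higher from compound 2 to compound 4 (beyond the scatter) and a number 25.7 percentage points higher from compound 1 to compound 4 (beyond the scatter) at the same place, which leaves compound 4 highest of the four. No measurement at hand accounts for this order of the groups.

Still open, as far as these compounds go, is whether an amine or a carboxylic acid at this place would stand above or below nitro. Also open, from the compounds shown here alone, is whether compound 4 keeps its lead at other concentrations.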